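The source may hold more compounds than are shown below. What is called first, only, known or untested is meant among the compounds shown, and "the series" means these compounds.

Measured so far:
compound 1, `C[C@H](c1ccc(C(=O)NCCC(=O)O)cc1)N1C(=O)C(c2cccc(F)c2)=N[C@]12CC[C@@H](C(C)(C)C)CC2`, 560 nM
compound 2, `CC(C)[C@H](c1ccc(C(=O)NCc2nn[nH]n2)cc1)N1C(=O)C(c2cc(Cl)cc(Cl)c2)=N[C@]12CC[C@@H](C(C)(C)C)CC2`, 2200 nM

In a functional assay on CHO cells for antagonist activity at Glucagon receptor (Homo sapiens), read by cAMP accumulation, with stated times of 30 min and 45 min (a lower number here means a stronger inhibitor, a higher number a weaker inhibitor), compound 1 holds the lower of the two numbers; compound 2 lies beyond the scatter above it. Compound 3, `C[C@H](c1ccc(C(=O)NCCC(=O)O)cc1)N1C(=O)C(c2cccc(Cl)c2F)=N[C@]12CC[C@@H](C(C)(C)C)CC2`, differs from compound 1 by 3-chloro-2-fluorophenyl in place of 3-fluorophenyl on a carbon with a double bond to nitrogen. Within the data shown here, no measured pair shows this change on its own, so its size is unknown; the expectation is a step of no more than the scatter, direction open, with a slight lean to a lower number. Compound 3 is therefore estimated at 450 nM, range 150 nM to 1400 nM. That estimate means a step of a 1.2-fold lower number from compound 1 to compound 3 (0.09 log units; within the scatter), expected to stay within the scatter.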

Compound 3, half-maximal inhibitory concentration: 630 nM
Beside the measured number, compound 3's estimate is 1.4-fold (0.15 log units) below it; measured number inside the range.
By their numbers in this assay, from the lowest: compounds 1 and 3 (each within the scatter of the next); then compound 2.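

On the carbon with a double bond to nitrogen, 3-chloro-2-fluorophenyl in place of 3-fluorophenyl gives a 1.1-fold higher number from compound 1 to compound 3 (0.05 log units; within the scatter) in this assay on the shared core. Among these compounds, this is the first single-place step, and it shows that this position takes one added chlorine and a moved fluorine pattern with no change beyond the scatter. Nothing at hand explains the size of this step.

As far as these compounds go, whether an amine or a methoxy group on this phenyl ring would hold the number remains open. So does the effect of a longer chain in place of the 3-aminopropanoic acid amide.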